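The compounds below may be only part of what the source reports. "The series", "measured", "known", "first", "only" and "open" are said of these compounds alone.

Compound 1 `Cc1cc(NC(=O)Cn2nnc(-c3ccc(Cl)c(Cl)c3)n2)n(C2CCCCC2)n1`: 84%
Compound 2 `Cc1cc(NC(=O)Cn2nnc(-c3cccc(F)c3)n2)n(C2CCCCC2)n1`: 96%

In an assay on HEK293 cells for activation of Kir3.1/Kir3.2 (Homo sapiens), read by thallium flux (on this read-out higher numbers stand for larger maximal responses and lower numbers for smaller maximal responses), compound 2 stands highest of the two measured compounds, with compound 1 giving 84%; the gap between them is a number 12 percentage points higher from compound 1 to compound 2 (beyond the scatter). Compound 3 `Cc1cc(NC(=O)Cn2nnc(-c3ccnc(F)c3)n2)n(C2CCCCC2)n1` differs from compound 2 in one place: 2-fluoropyridin-4-yl in place of 3-fluorophenyl on an aromatic carbon. Among the compounds with values here, no measured step exchanges a phenyl for a pyridinyl ring; the only measured step, a number 12 percentage points higher from compound 1 to compound 2 (beyond the scatter), concerns a different change of halogens and bears only loosely on this one. The step in this assay is therefore expected to stay within the usual scatter, estimated as a number 8 percentage points lower from compound 2 to compound 3 (within the scatter). Compound 3 is estimated at 88%, with a range from 70% to 105%.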

Compound 3, largest response reached (Emax), in percent of the reference or control that the assay uses: 95%
Compound 3: the middle estimate sits 7 percentage points below what was measured; the measured number falls inside the stated range.
By their numbers in this assay, from the lowest: compound 1; then compounds 3 and 2 (each within the scatter of the next).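

In this assay, the step of a number 1 percentage points lower from compound 2 to compound 3 (within the scatter) shows that the aromatic carbon of the five-membered ring with 4 nitrogen accepts 2-fluoropyridin-4-yl as readily as 3-fluorophenyl. The step of a number 11 percentage points higher from compound 1 to compound 3 (beyond the scatter) shows that the 2-fluoropyridin-4-yl group, like 3-fluorophenyl, stands apart from 3,4-dichlorophenyl, so a large response does not require a ring of carbon only. No evidence is available that accounts for these steps. Going by these compounds, it remains open whether an amine or a carboxylic acid could replace the fluorine of the 2-fluoropyridin-4-yl group with the response kept.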